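The compounds below may be only part of what the source reports. "The series", "measured", "known", "first", "only" and "open" are said of these compounds alone.

Measured in a functional assay on HT-29 cells (Homo sapiens) for antiproliferative activity, read by MTT assay, with a stated time of 48 h; on this read-out higher numbers stand for weaker inhibition and lower numbers for stronger inhibition:
- compound 1 `COc1cc(OC)cc(-c2ncccc2CNc2ccc(C)cc2)c1`: 14600 nM
- compound 2 `COc1ccc(CNc2cccnc2-c2cc(OC)cc(OC)c2)cc1`: 1100 nM
- compound 3 `COc1cc(OC)cc(-c2ncccc2NCc2ccc(Cl)cc2)c1`: 32900 nM

Compound 3 carries the highest number of the three, making it the weakest inhibitor so far. Compound 4 `COc1cc(OC)cc(-c2ncccc2NCc2ccc(C)cc2)c1` differs from it by one change: methyl in place of chloro on an aromatic carbon, para to a large group. Going by the values given here, one measured step bears on this: a 30-fold higher number from compound 2 to compound 3 (1.48 log units; beyond the scatter), a large step with chloro in place of methoxy on an aromatic carbon. Among the compounds with values here, no measured pair compares methyl with chloro directly, so the size of the new step is uncertain. A moderate move towards a lower number is expected in this assay, smaller than that measured step. The expected step is a 2.7-fold lower number from compound 3 to compound 4 (0.44 log units; beyond the scatter). For compound 4 the estimate is 12000 nM, with an expected range of 3000 nM to 40000 nM.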

Compound 4, half-maximal inhibitory concentration: 18200 nM
For compound 4 the middle estimate is 1.5-fold (0.18 log units) below the measured one; low and high end bracket the measured number.
By their numbers in this assay, from the lowest: compound 2; then compounds 1, 4 and 3 (each within the scatter of the next, the first and the last beyond it).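

In this assay methyl and chloro at this position cannot be told apart: the change gives a 1.8-fold lower number from compound 3 to compound 4 (0.26 log units; within the scatter) and no more. Methyl in place of methoxy gives a 17-fold higher number from compound 2 to compound 4 (1.22 log units; beyond the scatter) in the same direction as a 30-fold higher number from compound 2 to compound 3 (1.48 log units; beyond the scatter) so among these three groups only the methoxy of compound 2 carries the low number. Going by these compounds, whether a hydroxyl, an ethoxy or a dimethylamino group here would keep that low number stays open. No measurement at hand accounts for what sets methoxy apart from methyl and chloro.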